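Aromatic substituent swaps on a shared core

This account rests on a few compounds, and the source may have more. Where it says the series, first, only, none or still open, it means among the compounds named here.

Three measured compounds share one core and differ only in the group carried on an aromatic carbon. Compound 1 `O=C(CCC1=CCN(CCCc2ccc(Br)cc2)C1=O)NO` carries bromo, compound 2 `O=C(CCC1=CCN(CCCc2ccc(Cl)cc2)C1=O)NO` carries chloro and compound 3 `CCOc1ccc(CCCN2CC=C(CCC(=O)NO)C2=O)cc1` carries ethoxy. In a functional assay on PC-3 cells (Homo sapiens) for inhibition, read by sulforhodamine B assay (a lower number here means a stronger inhibitor of growth, a higher number a weaker inhibitor of growth), compound 1 gives 3480 nM, compound 2 gives 3480 nM and compound 3 gives 3480 nM. Compound 3 therefore stands level with the other two: the steps of no change at the digits printed from compound 1 to compound 3 (within the scatter) and no change at the digits printed from compound 2 to compound 3 (within the scatter) are both flat, as is no change at the digits printed from compound 1 to compound 2 (within the scatter) between the halogen pair.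

Compound 4 `CC(C)(C)c1ccc(CCCN2CC=C(CCC(=O)NO)C2=O)cc1` is still to be measured. It departs from compound 3 by the change (tert-butyl in place of ethoxy on an aromatic carbon), so tert-butyl now sits where compound 3 carries ethoxy. Within the data shown here, no measured step covers this exact swap. The three steps that do bear on it all exchange the group on the same aromatic carbon, and none of them moved the growth-inhibition reading beyond the scatter. On that basis the step of a 1.0-fold higher number from compound 3 to compound 4 (0.00 log units; within the scatter) is expected to stay within the scatter as well, with no direction favoured. Compound 4 is accordingly estimated at 3500 nM in this assay, with a range of 1600 nM to 7500 nM.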

Compound 4, concentration for 50% growth inhibition: 3480 nM
Estimate against measurement, compound 4: 1.0-fold (0.00 log units) above; the range from low to high includes it.
By their numbers in this assay, from the lowest: compounds 1, 2, 3 and 4 (each within the scatter of the next).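

In this assay, the step of no change at the digits printed from compound 3 to compound 4 (within the scatter) shows that this position, on an aromatic carbon para to a large group, also tolerates a group of carbon only: tert-butyl, with 0 hydrogen-bond acceptors, reads the same as ethoxy, with 1 hydrogen-bond acceptor. The halogen comparisons stay equally flat, with no change at the digits printed from compound 2 to compound 4 (within the scatter) and with no change at the digits printed from compound 1 to compound 4 (within the scatter), so bromo, chloro, ethoxy and tert-butyl are not separated by this read-out on the shared core. No supporting data are available to explain this flat result.

The compounds shown leave open whether an amine, a carboxylic acid or a phenyl ring at the same aromatic carbon would depart from the reading of compound 4 at 3480 nM in this assay. They also leave open whether the same insensitivity to the group at this position would hold with a shorter or longer chain in place of the one joining the aromatic ring to the core.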